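This account rests on a few compounds, and the source may have more. Where it says the series, first, only, none or still open, it means among the compounds named here.

Three compounds share one core and differ only in the group carried on an oxygen on a saturated carbon. Compound 1 `CCc1cccc2c(OC)c(-c3occ(C)c3CO)ccc12` carries hydrogen there; in a functional assay on ZR-75-1 cells (Homo sapiens) for cytotoxicity, read by MTT assay, with a stated time of 72 h (a lower number here means that less compound is needed, a higher number that more compound is needed for the effect), compound 1 gives > 10 ug/mL, which is a limit of the assay rather than a number. Compound 2 `CCOCc1c(C)coc1-c1ccc2c(CC)cccc2c1OC` carries ethyl, and in this assay compound 2 gives 9.1 ug/mL. Compound 3 `CCc1cccc2c(OC)c(-c3occ(C)c3COCC(F)(F)F)ccc12` carries 2,2,2-trifluoroethyl, and in this assay compound 3 gives 5.3 ug/mL, the lower of the two numbers shown, though the gap to its nearest neighbour, a 1.7-fold lower number from compound 2 to compound 3 (0.23 log units; within the scatter), is within the scatter. The steps of an at least 1.0-fold lower number from compound 1 to compound 2 (0.04 log units; that floor lies within the scatter) and an at least 1.8-fold lower number from compound 1 to compound 3 (0.27 log units; that floor lies within the scatter) are likewise small, and both start from a limit (the limit of > 10 ug/mL in this assay, at which 1 of the 3 values shown sits).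

Compound 4 `CCc1cccc2c(OC)c(-c3occ(C)c3COC(=O)CCN(CC)CC)ccc12` has not yet been measured. It differs from compound 3 by (2-(diethylamino)ethyl)carbonyl in place of 2,2,2-trifluoroethyl on an oxygen on a saturated carbon. For the measured compounds named here, none of the measured steps exchanges one substituent on that oxygen for another of this size; the three that exist all lie within the scatter, so no step beyond the scatter in this assay is expected in either direction, and the estimate is held loosely. For compound 4 the expected value in this assay is 7 ug/mL, with a range from 3 ug/mL to 20 ug/mL. The step this estimate implies is a 1.3-fold higher number from compound 3 to compound 4 (0.12 log units; within the scatter).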

Compound 4, concentration for half-maximal effect: 1.7 ug/mL
The estimate for compound 4 lay 4.1-fold (0.61 log units) above the measured number; the measured number lies below the stated range.
By their numbers in this assay, from the lowest: compound 4; then compounds 3 and 2 (each within the scatter of the next). At a limit, above all of these: compound 1.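

In this assay, for the compounds shown here, the place on an oxygen on a saturated carbon now yields steps beyond the scatter, which no exchange among the earlier compounds did: a 3.1-fold lower number from compound 3 to compound 4 (0.49 log units; beyond the scatter), and a 5.4-fold lower number from compound 2 to compound 4 (0.73 log units; beyond the scatter). The entering (2-(diethylamino)ethyl)carbonyl group is the only one shown that holds a carbonyl and a nitrogen, and the step of an at least 5.8-fold lower number from compound 1 to compound 4 (0.76 log units; beyond the scatter) also lies beyond the scatter, though it gives only a floor. Compound 1 stands at a limit of the assay and not at a number: the limit of > 10 ug/mL in this assay, at which 1 of the 4 values shown sits.

The compounds shown do not separate the carbonyl from the diethylamino end of the entering group, so it remains open whether a plain acetyl group on that oxygen, or a saturated chain ending in the same diethylamino group without a carbonyl, would give a similar number. Also open, going by these compounds, is how far the result depends on the amine itself, as a dimethylamino group, a piperidine or a longer chain to the nitrogen would show, and the numbers give no cause for the step.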